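Replacing the thiazole amide with a hydroxyethyl amide

The compounds below may be only part of what the source reports. "The series", "measured", "known", "first", "only" and "open" are said of these compounds alone.

Compound 1 `O=C(Nc1nccs1)c1cccc(Nc2ncc(F)c(Nc3ccc(F)cc3)n2)c1` is an amide built on a shared core that was tested in a functional assay on KB cells (Homo sapiens) for antiproliferative activity, read by sulforhodamine B assay, with a stated time of 3 days; a higher number here means a weaker inhibitor of growth, a lower number a stronger inhibitor of growth. In this assay compound 1 gives > 10000 nM, which is a limit of the assay and not a number. Compound 2 `COc1ccc(NC(=O)c2cccc(Nc3ncc(F)c(Nc4ccc(F)cc4)n3)c2)cc1` carries a 4-methoxyphenyl in place of the 1,3-thiazol-2-yl on the amide-type nitrogen. In this assay compound 2 gives > 10000 nM, again a limit. The step that the two limits leave unreadable from compound 1 to compound 2 cannot be read because both values sit at the limit of > 10000 nM in this assay, at which 2 of the 2 values shown sit.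

Compound 3 `O=C(NCCO)c1cccc(Nc2ncc(F)c(Nc3ccc(F)cc3)n2)c1` differs from compound 1 by 2-hydroxyethyl in place of 1,3-thiazol-2-yl on an amide-type nitrogen. Among the measured compounds shown here, no measured step with a readable size bears on this change; the only step at hand, from compound 1 to compound 2, is unreadable. The step that the limit leaves unreadable from compound 1 to compound 3 is therefore only an expectation, with nothing measured behind it. Compound 3 is expected to give 15000 nM in this assay, with a range from 4000 nM to 60000 nM.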

Compound 3, concentration for 50% growth inhibition: 12400 nM
Compound 3: middle estimate off by 1.2-fold (0.08 log units), on the high side; measured number inside the range.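

Compound 3 gives a readable number, while compound 1 and compound 2 stand only at a limit of the assay, and the steps from each of them to compound 3 cannot be read. The compounds shown leave open whether 2-hydroxyethyl on the amide-type nitrogen does better or worse than 1,3-thiazol-2-yl or 4-methoxyphenyl.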